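A Methyl on the Core Ring of Compound 1

The compounds below may be only part of what the source reports. "The series", "measured", "known", "first", "only" and "open" are said of these compounds alone.

Compound 1 `Cn1c(SCC(=O)N2CCC[C@H]2C(=O)Nc2ccccc2-n2cccc2)nc2ccccc21` stands second highest of the three numbers in an assay on CHO cells for displacement of a labelled ligand from Orexin/Hypocretin receptor type 1 (Homo sapiens) (a higher number here means a weaker inhibitor, a lower number a stronger inhibitor), where compound 1 gives 9 nM. Compound 2 `Cn1c(SCC(=O)N2CCC[C@H]2C(=O)Nc2ccccc2-c2ccccc2)nc2ccccc21` gives 3 nM, a step of a 3.0-fold lower number from compound 1 to compound 2 (0.48 log units; beyond the scatter), and compound 3 `O=C(Nc1ccccc1-n1cccc1)[C@@H]1CCCN1C(=O)CCc1nc2ccccc2[nH]1` gives 130 nM, a step of a 14-fold higher number from compound 1 to compound 3 (1.16 log units; beyond the scatter). Compound 4 `Cc1ccc2c(c1)nc(SCC(=O)N1CCC[C@H]1C(=O)Nc1ccccc1-n1cccc1)n2C` differs from compound 1 by methyl in place of hydrogen on an aromatic carbon. Neither measured step touches this spot: the step to compound 2 alters a different aromatic carbon, and the step to compound 3 alters the chain bound to the carbonyl carbon. Nothing measured bears directly on this added methyl, so the expected change is none beyond the scatter. Compound 4 is therefore expected to give about 9 nM, between 3 nM and 27 nM, which means an expected step of no change at the digits printed from compound 1 to compound 4 (within the scatter).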

Compound 4, inhibition constant: 0.7 nM
Beside the measured number, compound 4's estimate is 13-fold (1.11 log units) above it; the measured number lies below the stated range.
By their numbers in this assay, from the lowest: compound 4; then compound 2; then compound 1; then compound 3.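

In this assay, within the data shown here, the change from 1-methyl-1H-benzimidazol-2-yl to 1,5-dimethyl-1H-benzimidazol-2-yl gives a 13-fold lower number from compound 1 to compound 4 (1.11 log units; beyond the scatter) and so shows that this aromatic carbon, untouched by the earlier steps, is not indifferent to substitution. A single added methyl, one heavy atom, is enough for a large step toward a lower number. Nothing available explains this step. From the compounds shown here alone, whether chlorine, methoxy or ethyl on the same carbon would move the number as methyl does remains open. So does whether the methyl would have the same effect with the phenyl of compound 2 in place of 1H-pyrrol-1-yl.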